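A few compounds are considered here, and "the series" means these few. Any claim that something is new, unique, unknown or untested is made for them only; others in the source may bear on it.

Measured in a functional assay on MCF7 cells (Homo sapiens) for antiproliferative activity, read by MTT assay, with a stated time of 48 h; on this read-out higher numbers stand for weaker inhibition and lower numbers for stronger inhibition:
- Compound 1 `CCn1c(C(=O)NCC#N)ccc1C(CC)(CC)c1ccc(OCCC(O)(CC)CC)c(C)c1`: > 50000 nM, a limit of the assay
- Compound 2 `CCn1c(C(=O)Nc2ccc(OC(F)(F)F)cc2)ccc1C(CC)(CC)c1ccc(OCCC(O)(CC)CC)c(C)c1`: > 50000 nM, a limit of the assay
- Compound 3 `CCn1c(C(=O)N(C)CCO)ccc1C(CC)(CC)c1ccc(OCCC(O)(CC)CC)c(C)c1`: 2870 nM

Among these three, compound 3 alone has a true number, while the other two stop at the limit of > 50000 nM in this assay, at which 2 of the 3 values shown sit. Compound 4 `CCn1c(C(=O)NC(C)CO)ccc1C(CC)(CC)c1ccc(OCCC(O)(CC)CC)c(C)c1` has the same atoms as compound 3, joined differently: (1-(hydroxymethyl)ethyl)amino in place of (2-hydroxyethyl)(methyl)amino on a carbonyl carbon. On the carbonyl carbon, (1-(hydroxymethyl)ethyl)amino stands in place of (2-hydroxyethyl)(methyl)amino.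

Within the data shown here, two measured steps bear on this change, as both alter the group on that same carbonyl carbon. One is an at least 17-fold lower number from compound 1 to compound 3 (1.24 log units; beyond the scatter), and the other is an at least 17-fold lower number from compound 2 to compound 3 (1.24 log units; beyond the scatter). Both are large, so the read-out can respond strongly to changes at this place. Neither step matches the present change, however. Compound 4 keeps a hydroxyl-bearing chain, as compound 3 does, but it also has an amide hydrogen, as compound 1 and compound 2 do. Among the measured compounds shown here, no measured pair separates these two features. A moderate move toward weaker inhibition in this assay is therefore expected, though a result within the scatter would not be surprising. The expected change is a 1.7-fold higher number from compound 3 to compound 4 (0.24 log units; within the scatter). For compound 4 the estimated value is 5000 nM, with an expected range from 1500 nM to 30000 nM.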

Compound 4, half-maximal inhibitory concentration: 12600 nM
The estimate for compound 4 lay 2.5-fold (0.40 log units) below the measured number, and the stated range covers the measured number.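

In this assay, the read-out separates two groups built from the same atoms on the carbonyl carbon, with a 4.4-fold higher number from compound 3 to compound 4 (0.64 log units; beyond the scatter), so the arrangement of those atoms matters here and not only their kind. Compound 4 still gives a true number, and with 1-(hydroxymethyl)ethyl on the amide-type nitrogen the read-out shows an at least 3.9-fold lower number from compound 2 to compound 4 (0.59 log units; beyond the scatter) and an at least 3.9-fold lower number from compound 1 to compound 4 (0.59 log units; beyond the scatter), so among the compounds shown an amide hydrogen does not by itself put a compound at the limit. Those two steps are bounds rather than sizes, as compound 1 and compound 2 each stop at a limit of the assay: the limit of > 50000 nM in this assay, at which 2 of the 4 values shown sit.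

Among these compounds, the compounds measured so far do not separate the amide hydrogen from the branched chain. A (2-hydroxyethyl)amino group on the same carbonyl carbon would help to part the two. From the compounds shown here alone, how an amine or a carboxylic acid at the end of such a chain, or a longer hydroxyalkyl chain, would read at this place also remains open.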